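Swapping an indole acid for a lactam on the shared core

The source may report more compounds than this note shows. Statements on the series, on what has been measured and on what is new or still open speak of the compounds shown alone.

Compound 1, `Cn1c(=O)c(S(=O)(=O)c2ccc(F)cc2F)cc2cnc(Nc3ccc4[nH]c(C(=O)O)cc4c3)nc21`: 10000 nM
Compound 2, `Cn1c(=O)c(S(=O)(=O)c2ccc(F)cc2N)cc2cnc(Nc3ccc4[nH]ccc4c3)nc21`: 3000 nM

In a functional assay on DU-145 cells (Homo sapiens) for inhibition, read by trypan blue exclusion, with a stated time of 72 h (a higher number here means a weaker inhibitor, a lower number a stronger inhibitor), compound 1 gives 10000 nM, the highest of the two numbers. Compound 2 gives 3000 nM, a difference that lies beyond the usual scatter.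

Compound 3, `Cn1c(=O)c(S(=O)(=O)c2ccc(F)cc2F)cc2cnc(Nc3ccc4c(c3)CC(=O)N4)nc21`, has not been measured. It differs from compound 1 at the nitrogen on the aromatic ring: a group of 10 heavy atoms (8 carbon, 1 nitrogen, 1 oxygen; one five-membered non-aromatic ring with 1 hetero atom, one six-membered aromatic ring of carbon only) in place of a group of 12 heavy atoms (9 carbon, 1 nitrogen, 2 oxygen; one five-membered aromatic ring with 1 hetero atom, one six-membered aromatic ring of carbon only), on a nitrogen on an aromatic ring

The replacement removes the carboxylic acid group of compound 1 while keeping a two-ring system at the same place. Going by the values given here, with no measured pair that isolates this change, the step from compound 1 to compound 3 is expected to be a modest one toward a lower number, as a 2.5-fold lower number from compound 1 to compound 3 (0.40 log units; beyond the scatter) expresses. For compound 3 in this assay the estimate is 4000 nM, within 1000 nM to 15000 nM.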

Compound 3, half-maximal inhibitory concentration: 100000 nM
Compound 3: the middle estimate sits 25-fold (1.40 log units) below what was measured, and the stated range ends below it.
By their numbers in this assay, from the lowest: compound 2; then compound 1; then compound 3.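

Changing the group on this nitrogen on an aromatic ring, in this assay, gives a 10-fold higher number from compound 1 to compound 3 (1.00 log units; beyond the scatter), so the activity responds clearly to the group at this place. Losing the carboxylic acid and the aromatic five-membered ring together, in favour of the non-aromatic five-membered ring, brings no gain on this core. Nothing measured here accounts for this step.

As far as these compounds go, because the acid and the ring change at once, their separate contributions remain unknown. A methyl ester or a primary amide in place of the carboxylic acid, with the aromatic ring kept, would separate them.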